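Extending the ether chain on the lactone series

The compounds below may be only part of what the source reports. "The series", "measured", "known", "first", "only" and "open" are said of these compounds alone.

Values in a functional assay on HL-60 cells (Homo sapiens) for cytotoxicity, read by WST assay, with a stated time of 48 h; on this read-out higher numbers stand for an effect only at larger amounts of compound and lower numbers for an effect already at smaller amounts:
- compound 1 `O=C1OC[C@H](Cc2ccccc2)[C@H]1Cc1ccccc1O`: 83000 nM
- compound 2 `COCOc1ccccc1C[C@H]1C(=O)OC[C@@H]1Cc1ccccc1`: 76000 nM

For the measured compounds named here, compound 2 can be compared only with compound 1, and the two values cannot be separated: the single measured step is a 1.1-fold lower number from compound 1 to compound 2 (0.04 log units; within the scatter). Compound 2 therefore stands level with compound 1 in this assay.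

Compound 3 `CCCCCCCOc1ccccc1C[C@H]1C(=O)OC[C@@H]1Cc1ccccc1` is the next case, with hexyl in place of methoxy on a saturated chain carbon bound to an oxygen on an aromatic ring. This puts hexyl in place of methoxy on a saturated chain carbon bound to an oxygen on an aromatic ring. Cut one bond further out, the same difference reads methoxymethyl to heptyl.

Going by the values given here, the one measured step bears on this only loosely. It concerns methoxymethyl in place of hydrogen on that oxygen, and no chain of this length has been measured. A large shift is thus not supported, and the direction is only weakly held. The expected change is a 1.9-fold lower number from compound 2 to compound 3 (0.28 log units; within the scatter), a modest move that may not clear the scatter. For compound 3 the estimated value is 40000 nM, with an expected range of 12000 nM to 95000 nM.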

Compound 3, half-maximal effective concentration: 75000 nM
The estimate for compound 3 lay 1.9-fold (0.27 log units) below the measured number; the measured number falls inside the stated range.
By their numbers in this assay, from the lowest: compounds 3, 2 and 1 (each within the scatter of the next).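

At the oxygen on the aromatic ring, hexyl in place of methoxy on the saturated chain carbon gives, in this assay, a 1.0-fold lower number from compound 2 to compound 3 (0.01 log units; within the scatter), so the heptyl ether cannot be told apart from the methoxymethyl ether. Heptyl in place of hydrogen on that oxygen gives a 1.1-fold lower number from compound 1 to compound 3 (0.04 log units; within the scatter), so a chain of this length also cannot be separated from the free oxygen, a reading that earlier rested only on the methoxymethyl group. No supporting measurement bears on why this position shows so little response in this read-out.

With all three compounds within the scatter of one another, it remains open whether any group on this oxygen can move the number beyond the scatter, and the compounds shown give no lead on which kind of group might do so. An amine or a carboxylic acid at the end of the chain, or a chain longer than heptyl, would test this position in a way that these simple ethers do not.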